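The source may hold more compounds than are shown below. What is called first, only, known or untested is meant among the compounds shown, and "the series" means these compounds.

Compound 1 `COc1ccc(CN(c2cc(OC)c(OC)c(OC)c2)S(=O)(=O)c2ccc(C(C)(C)C)cc2)cc1`, compound 2 `COc1ccc(CN(c2cc(OC)c(OC)c(OC)c2)S(=O)(=O)c2ccc(OC)c(OC)c2)cc1` and compound 3 `COc1ccc(CN(c2cc(OC)c(OC)c(OC)c2)S(=O)(=O)c2c(C)cc(C)cc2C)cc1` share one core and differ only in the group on a sulfonyl sulfur. In a functional assay on PC-3 cells (Homo sapiens) for inhibition, read by MTT assay, with a stated time of 48 h (a higher number here means a weaker inhibitor, a lower number a stronger inhibitor), compound 1 gives 28600 nM, compound 2 gives 20100 nM and compound 3 gives 14800 nM. Compound 2 stands second highest of the three, and its gaps to the others are small: a 1.4-fold lower number from compound 1 to compound 2 (0.15 log units; within the scatter) and a 1.4-fold lower number from compound 2 to compound 3 (0.13 log units; within the scatter). Compound 4 `COc1ccc(S(=O)(=O)N(Cc2nc3ccccc3[nH]2)c2cc(OC)c(OC)c(OC)c2)cc1OC` arises from compound 2 by a change at a different place: 1H-benzimidazol-2-yl in place of 4-methoxyphenyl on a saturated chain carbon bound to a sulfonamide nitrogen. Within the data shown here, none of the measured steps touches this place; all of them concern the group on a sulfonyl sulfur and all lie within the scatter, so they offer no guide. On the numbers of compound 2 alone, the expected step is a 1.0-fold lower number from compound 2 to compound 4 (0.00 log units; within the scatter). Compound 4 is expected at 20000 nM, ranging from 7000 nM to 60000 nM.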

Compound 4, half-maximal inhibitory concentration: 30400 nM
Compound 4: the middle estimate sits 1.5-fold (0.18 log units) below what was measured; the range from low to high includes it.
By their numbers in this assay, from the lowest: compounds 3, 2, 1 and 4 (each within the scatter of the next, the first and the last beyond it).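

In this assay, among these compounds, the first change at the saturated chain carbon bound to the sulfonamide nitrogen gives a step within the scatter (a 1.5-fold higher number from compound 2 to compound 4 (0.18 log units; within the scatter)). So 1H-benzimidazol-2-yl, with its two aromatic rings and a hydrogen-bond donor that 4-methoxyphenyl lacks, cannot be told apart from 4-methoxyphenyl here. Nothing shown explains this result.

Among the compounds shown here, with only this one pair at this place, it remains open whether a different group there, such as a pyridine ring, a carboxylic acid or an amine, would move the number beyond the scatter. From the compounds shown here alone, it is also open whether 1H-benzimidazol-2-yl would behave the same alongside the other groups on the sulfonyl sulfur.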